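The source may hold more compounds than are shown below. What is called first, only, known or untested is meant among the compounds shown, and "the series" means these compounds.

Working notes on the series. Compound 1 `CSC1(C)C(=O)N(c2ccccc2)c2ncccc21` is the reference point; in a functional assay on the whole organism (Pleural cavity) for inhibition, with Rattus norvegicus as the target, at a dose of 25 mg/kg (on this read-out higher numbers stand for more inhibition at the one dose given (going by the name of the read-out) and lower numbers for less inhibition), compound 1 gives 53%. For the measured compounds named here, compound 2 `CC1(C)C(=S)N(c2ccc(Cl)cc2)c2ncccc21` is the only other measured member, and in this assay compound 2 gives 42%. Of the two numbers, compound 1 is the higher one. The gap between compound 1 and compound 2 is larger than the usual scatter of repeated measurements, and compound 1 stands clearly on top of what has been measured so far.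

Compound 3 `CC1C(=O)N(c2ccccc2)c2ncccc21` has not yet been run in this assay. Against compound 1 the change is hydrogen in place of methylsulfanyl on a saturated ring carbon. Going by the values given here, no pair of measured compounds isolates this change, so the step from compound 1 to compound 3 is judged without direct precedent. It is expected to be a modest loss, possibly not beyond the scatter, expressed as a number 13 percentage points lower from compound 1 to compound 3 (beyond the scatter). Compound 3 is therefore estimated at 40%, within a range of 15% to 62%.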

Compound 3, a percentage reported as inhibition, in the whole organism at one dose (the size of the read-out at that dose, not a potency): 18%
The estimate for compound 3 lay 22 percentage points above the measured number; low and high end bracket the measured number.
By their numbers in this assay, from the lowest: compound 3; then compound 2; then compound 1.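

In this assay, replacing methylsulfanyl with hydrogen gives a number 35 percentage points lower from compound 1 to compound 3 (beyond the scatter), a large step beyond the scatter. For the compounds shown here, this is the first direct reading at this position: the saturated ring carbon, two ring bonds from the ring nitrogen, is not indifferent to what it carries, and within this pair the methylsulfanyl group goes with the higher inhibition at the one dose given. Nothing at hand bears on why the step is this large.

From the compounds shown here alone, whether this inhibition depends on methylsulfanyl specifically or would persist with another group on this carbon remains open, for example with methoxy, ethylsulfanyl or an amine. Also open, going by these compounds, is whether the same change would give a step of similar size on the core of compound 2.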